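This account rests on a few compounds, and the source may have more. Where it says the series, first, only, none or still open, it means among the compounds named here.

Two compounds of this series have numbers in a functional assay on HL-60 cells (Homo sapiens) for antiproliferative activity, with a stated time of 24 h; a higher number here means a weaker inhibitor, a lower number a stronger inhibitor. Compound 1 `NC(=O)c1c(NC(=O)c2ccccc2Cl)sc2c1CCN(Cc1ccccc1Cl)C2` gives 2900 nM in this assay, the lowest of the two numbers. Compound 2 `NC(=O)c1c(NC(=O)c2cccc([N+](=O)[O-])c2)sc2c1CCN(Cc1c(Cl)cccc1Cl)C2` gives 18400 nM in this assay, a higher number that lies beyond the scatter; compound 2 differs from compound 1 in more than one place, so no single step can be read from the pair.

Compound 3 `NC(=O)c1c(NC(=O)c2ccccc2Cl)sc2c1CCN(C(=S)Nc1ccccc1I)C2` is not yet measured. It differs from compound 1 as follows: a group of 10 heavy atoms (7 carbon, 1 nitrogen, 1 sulfur, 1 iodine; one six-membered aromatic ring of carbon only) in place of a group of 8 heavy atoms (7 carbon, 1 chlorine; one six-membered aromatic ring of carbon only), on an amine nitrogen in a ring. Among the compounds with values here, no measured pair tests a change at this position, so the direction of the step cannot be read from the data. Given the size of the change, a step beyond the scatter is possible in either direction; compound 3 is expected to give 4500 nM in this assay, within a range of 1000 nM to 20000 nM, which corresponds to an expected step of a 1.6-fold higher number from compound 1 to compound 3 (0.19 log units; within the scatter).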

Compound 3, half-maximal inhibitory concentration: 4430 nM
Estimate against measurement, compound 3: 1.0-fold (0.01 log units) above; low and high end bracket the measured number.
By their numbers in this assay, from the lowest: compounds 1 and 3 (each within the scatter of the next); then compound 2.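

In this assay, within the data shown here, the step of a 1.5-fold higher number from compound 1 to compound 3 (0.18 log units; within the scatter) is the first reading at the amine nitrogen in a ring, and it shows that this position accepts the group of 10 heavy atoms in place of 2-chlorobenzyl without a step beyond the scatter. The entering group brings a double bond outside aromatic rings, a hydrogen-bond donor and a hydrogen-bond acceptor, and this single pair shows none of these additions moving the number beyond the scatter. Nothing measured on these compounds accounts for this result.

The step changes the atoms joining the aromatic ring to the nitrogen and the halogen together, so their separate contributions stay unresolved. From the compounds shown here alone, whether a simple methyl group, an aminoethyl chain or a carboxylic acid at the same nitrogen would also stay within the scatter remains open.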